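Swapping a dichlorophenyl for a dimethylpyrazole on the ether arm

A few compounds are considered here, and "the series" means these few. Any claim that something is new, unique, unknown or untested is made for them only; others in the source may bear on it.

Compound 1 `Cc1nn(-c2ncnc3nc[nH]c23)c2c1C(OCc1ccc(Cl)cc1Cl)CC(=O)N2` carries a 2,4-dichlorobenzyl ether on the shared core. In a functional assay on HEK293 cells for agonist activity at G-protein coupled receptor 39 (Homo sapiens), read by scintillation proximity assay and inositol phosphate accumulation, with a stated time of 75 min (a higher number here means that more compound is needed for the effect, a lower number that less compound is needed), compound 1 gives 243 nM, the lowest of the two numbers recorded. Compound 2 `Cc1nn(-c2ncnc3nc[nH]c23)c2c1C(C(=O)NCc1ccc(F)cc1)CC(=O)N2` has an amide-linked fluorobenzyl arm instead, and in this assay compound 2 gives 1220 nM, a gap beyond the scatter, though the two differ in more than one place, so no single step can be read from that pair.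

Compound 3 `Cc1cc(C)n(CCOC2CC(=O)Nc3c2c(C)nn3-c2ncnc3nc[nH]c23)n1` keeps the ether linkage of compound 1 and differs from it by (3,5-dimethyl-1H-pyrazol-1-yl)methyl in place of 2,4-dichlorophenyl on a saturated chain carbon bound to an oxygen on a saturated carbon. Among the compounds with values here, no measured pair shows this kind of exchange, so the direction must be guessed from the single anchor. He expects the step of a 6.2-fold higher number from compound 1 to compound 3 (0.79 log units; beyond the scatter) to be a loss beyond the scatter, and estimates that compound 3 will give 1500 nM in this assay, with a plausible range from 300 nM to 8000 nM.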

Compound 3, half-maximal effective concentration: 2000 nM
Compound 3: the middle estimate sits 1.3-fold (0.12 log units) below what was measured, and the stated range covers the measured number.
By their numbers in this assay, from the lowest: compound 1; then compounds 2 and 3 (each within the scatter of the next).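

With compound 3, the ether arm of the shared core gets its first step that differs in one place. In this assay, replacing 2,4-dichlorophenyl with (3,5-dimethyl-1H-pyrazol-1-yl)methyl gives an 8.2-fold higher number from compound 1 to compound 3 (0.92 log units; beyond the scatter), so this position on the chain responds to the exchange, even though the leaving and entering groups have the same heavy-atom count. The entering group has 2 hydrogen-bond acceptors and the leaving group has 0, but nothing measured here explains the step.

Read one bond further out, the change is from 2,4-dichlorobenzyl to 2-(3,5-dimethyl-1H-pyrazol-1-yl)ethyl, so the compounds shown do not separate the effect of the ring from that of the chain. On these data alone, a 2-phenylethyl ether would address that question, while an unsubstituted benzyl ether or an amine at the end of the arm remains open.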